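The source may hold more compounds than are shown below. What is called first, only, known or untested is meant among the compounds shown, and "the series" means these compounds.

Measured compounds:
- compound 1, `c1ccc(-c2ccnc(Nc3ccc(-n4ccnc4)cc3)n2)nc1`, gives 1400 nM in a functional assay for inhibition, with Homo sapiens as the target; a lower number here means a stronger inhibitor, a higher number a weaker inhibitor
- compound 2, `CCc1ccc(Nc2nccc(-c3ccccn3)n2)cc1`, gives 2100 nM
- compound 3, `CN(C)c1ccc(Nc2nccc(-c3ccccn3)n2)cc1`, gives 3300 nM

All three share the same core and differ only in one group on an aromatic carbon of a six-membered carbon-only ring. Compound 3 has the highest number of the three: its step from compound 1 is a 2.4-fold higher number from compound 1 to compound 3 (0.37 log units; beyond the scatter), while its step from compound 2 is a 1.6-fold higher number from compound 2 to compound 3 (0.20 log units; within the scatter) and so cannot be told apart from compound 2 by this measurement alone.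

Compound 4, `CC1CCN(c2ccc(Nc3nccc(-c4ccccn4)n3)cc2)CC1`, is not yet measured. It differs from compound 3 in one place: 4-methylpiperidin-1-yl in place of dimethylamino on an aromatic carbon. The group that enters sits on the same aromatic carbon, para to a large group, as the group that leaves.

Going by the values given here, no measured step swaps one group for a ring-bearing group of this kind, so the only guide is how little the three measured groups moved the number: a 1.5-fold higher number from compound 1 to compound 2 (0.18 log units; within the scatter) and a 1.6-fold higher number from compound 2 to compound 3 (0.20 log units; within the scatter) are both within the scatter, and a 2.4-fold higher number from compound 1 to compound 3 (0.37 log units; beyond the scatter) is only modest. On that basis compound 4 is expected to stay near compound 3, with a 1.1-fold lower number from compound 3 to compound 4 (0.04 log units; within the scatter) as the estimated step. For compound 4 the estimate is 3000 nM, with a range from 1200 nM to 8000 nM.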

Compound 4, half-maximal inhibitory concentration: 1900 nM
Beside the measured number, compound 4's estimate is 1.6-fold (0.20 log units) above it; the range from low to high includes it.
By their numbers in this assay, from the lowest: compounds 1, 4, 2 and 3 (each within the scatter of the next, the first and the last beyond it).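

In this assay, putting 4-methylpiperidin-1-yl on this aromatic carbon gives a 1.7-fold lower number from compound 3 to compound 4 (0.24 log units; within the scatter), a 1.1-fold lower number from compound 2 to compound 4 (0.04 log units; within the scatter) and a 1.4-fold higher number from compound 1 to compound 4 (0.13 log units; within the scatter). Going by these compounds alone, this is the first group at this place with a six-membered non-aromatic ring, and with its 7 heavy atoms it still leaves the number within the scatter of all three earlier compounds, so this position accepts such a ring without any change this measurement can resolve. Within the data shown here, the only pair still told apart is the earlier one of the imidazole and dimethylamino compounds, and nothing available explains how these groups behave at this place.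

On these data alone, it remains open whether the methyl on the ring matters, which the plain piperidin-1-yl group would test, and whether a ring with a second nitrogen, such as piperazin-1-yl, or a carboxylic acid at this same carbon would move the number beyond the scatter. As far as these compounds go, all four compounds also keep the shared core unchanged, so how much changes elsewhere on it would shift the number also stays open.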